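Working notes: triazole substituent change in the dithioethyl nucleoside series

This account rests on a few compounds, and the source may have more. Where it says the series, first, only, none or still open, it means among the compounds named here.

Measured so far in a functional assay on A549 cells (Homo sapiens) for cytotoxicity, read by MTT assay, with a stated time of 72 h; on this read-out lower numbers stand for an effect already at smaller amounts and higher numbers for an effect only at larger amounts of compound:
- compound 1 `CCOC(=O)c1cn(C[C@H]2O[C@@H](n3ccc(=O)[nH]c3=O)[C@H](SCC)[C@@H]2SCC)nn1`: >= 100000 nM
- compound 2 `CCS[C@@H]1[C@H](SCC)[C@@H](Cn2cc(-c3ccc(OC)cc3)nn2)O[C@H]1n1cc(C)c(=O)[nH]c1=O`: 38800 nM
- compound 3 `CCS[C@@H]1[C@H](SCC)[C@@H](Cn2cc(-c3ccc(C)cc3)nn2)O[C@H]1n1cc(C)c(=O)[nH]c1=O`: 12300 nM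

The value of compound 1 is a limit of this assay, not a number. Among the two numbers shown, compound 3 stands at the lowest; its nearest neighbour is compound 2, and the step of a 3.2-fold lower number from compound 2 to compound 3 (0.50 log units; beyond the scatter) lies beyond the scatter.

Compound 4 `CCOC(=O)c1cn(C[C@H]2O[C@@H](n3cc(C)c(=O)[nH]c3=O)[C@H](SCC)[C@@H]2SCC)nn1` is not yet measured. It differs from compound 3 by ethoxycarbonyl in place of 4-methylphenyl on an aromatic carbon. Among the compounds with values here, no measured step covers an exchange of an aryl group for an ethoxycarbonyl group, so the only measured step, from compound 2 to compound 3, concerns a different kind of change and bears on this one only in showing that the group at this place can shift the number by a modest amount. Compound 1, which carries the same ethoxycarbonyl group at the same place but differs from compound 4 elsewhere in the core, sits at the limit (the limit of >= 100000 nM in this assay, at which 1 of the 3 values shown sits). The expected step is therefore an 8.1-fold higher number from compound 3 to compound 4 (0.91 log units; beyond the scatter), towards higher numbers, with a fair chance that compound 4 likewise reaches only a limit. Compound 4 is estimated at 100000 nM, within 30000 nM to 300000 nM.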

Compound 4, half-maximal effective concentration: >= 100000 nM
Compound 4 ended at the assay's limit; the forecaster's own chance of this, stated with the estimate: 60%; the middle value lies on the limit itself.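

In this assay, replacing the aryl group on this aromatic carbon of the five-membered ring with ethoxycarbonyl gives an at least 8.1-fold higher number from compound 3 to compound 4 (0.91 log units; beyond the scatter), and the corresponding exchange of 4-methoxyphenyl gives an at least 2.5-fold higher number from compound 2 to compound 4 (0.41 log units; beyond the scatter), so on this core both aryl compounds give measured numbers while the ethoxycarbonyl compound reaches only a limit. As far as these compounds go, the step from compound 1 to compound 4 cannot be read, as both values are limits, so the effect of methyl in place of hydrogen on the other aromatic ring remains unknown. Ethoxycarbonyl at this place now goes with the limit on both the core of compound 1 and the core of compound 4: the limit of >= 100000 nM in this assay, at which 2 of the 4 values shown sit.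

The compounds shown leave open whether the measured numbers need an aromatic ring at this place at all, or whether a carboxylic acid, a primary amide or a simple alkyl chain on the same carbon would also give a measured number. Also open, from the compounds shown here alone, is the effect of the methyl group where an aryl group occupies this place, which would take two 4-methylphenyl compounds differing only in that methyl.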